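Cyclopropyl amide in place of a flexible chain

The compounds below may be only part of what the source reports. "The series", "measured", "known", "first", "only" and "open" are said of these compounds alone.

Measured so far:
Compound 1, `Cc1nc(-c2ccc(C(F)(F)F)cc2)sc1CNc1ccc(CC(=O)O)cc1`: < 10000 nM
Compound 2, `Cc1nc(-c2ccc(C(F)(F)F)cc2)sc1CNc1ccc(/C=C/C(=O)O)cc1`: 36.3 nM
Compound 3, `Cc1nc(-c2ccc(C(F)(F)F)cc2)sc1CNc1ccc(CCC(N)=O)cc1`: 12.9 nM

All three share one core and differ only in the group on the six-membered aromatic ring of carbon only. In a functional assay on CHO cells for agonist activity at Free fatty acid receptor 1 (Homo sapiens) (a lower number here means that less compound is needed, a higher number that more compound is needed for the effect), compound 3 gives 12.9 nM, the lowest of the two numbers available. Its nearest neighbour is compound 2, and the step of a 2.8-fold lower number from compound 2 to compound 3 (0.45 log units; beyond the scatter) is modest but clear. For compound 1 the value < 10000 nM is a limit of the assay, not a number. Because of that the limit of < 10000 nM in this assay, at which 1 of the 3 values shown sits, the steps a step that the limit leaves unreadable from compound 1 to compound 2 and a step that the limit leaves unreadable from compound 1 to compound 3 cannot be sized.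

Compound 4, `Cc1nc(-c2ccc(C(F)(F)F)cc2)sc1CNc1ccc([C@H]2C[C@@H]2C(=O)N(C)C)cc1`, is not yet measured. It differs from compound 3 by 2-(dimethylcarbamoyl)cyclopropyl in place of 2-carbamoylethyl on an aromatic carbon. Among the measured compounds shown here, no measured step involves a ring of this kind or a dimethylated amide, so the only guide is that a change of similar reach, the step of a 2.8-fold lower number from compound 2 to compound 3 (0.45 log units; beyond the scatter), stayed modest. A step of comparable size in either direction is therefore expected, with no strong reason to favour a large one. Compound 4 is estimated at 25 nM in this assay, ranging from 6 nM to 100 nM, which would be a step of a 1.9-fold higher number from compound 3 to compound 4 (0.29 log units; within the scatter).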

Compound 4, half-maximal effective concentration: 66.1 nM
Compound 4: the middle estimate sits 2.6-fold (0.42 log units) below what was measured; the range from low to high includes it.
By their numbers in this assay, from the lowest: compound 3; then compounds 2 and 4 (each within the scatter of the next).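

Replacing 2-carbamoylethyl with 2-(dimethylcarbamoyl)cyclopropyl, a larger group with a three-membered ring, two defined stereocentres and no hydrogen-bond donor, gives in this assay a 5.1-fold higher number from compound 3 to compound 4 (0.71 log units; beyond the scatter), so the position on the six-membered aromatic ring still accepts this group but the number rises. The comparison with the 2-carboxyethenyl group gives a 1.8-fold higher number from compound 2 to compound 4 (0.26 log units; within the scatter), which means that in this assay these two groups, one an amide with no net charge and the other a carboxylic acid, cannot be told apart. Compound 1 carries a limit and not a number, so no step from it, including the one to compound 4, can be read: the limit of < 10000 nM in this assay, at which 1 of the 4 values shown sits.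

The compounds shown leave open which part of the change carries the step from the amide chain to the ring amide, the three-membered ring or the two methyl groups on the amide nitrogen. Also open, going by these compounds, is how a cyclopropyl group bearing a plain carbamoyl or a carboxylic acid would read, and whether the mirror-image arrangement at the two stereocentres would give a similar number.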